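Swapping the pyridin-2-yl of compound 1 for thiophen-3-yl

The compounds below may be only part of what the source reports. "The series", "measured", "known", "first", "only" and "open" are said of these compounds alone.

Compound 1 `OC[C@H]1OC(n2cnc3c(-c4ccccn4)ncnc32)[C@H](O)[C@@H]1O` is one of three closely related compounds measured in a functional assay on CCRF-CEM cells (Homo sapiens) for inhibition (a lower number here means a stronger inhibitor, a higher number a weaker inhibitor), where compound 1 gives 900 nM. That places compound 1 second highest of the three; compound 3 `OC[C@H]1OC(n2cnc3c(-c4cc[nH]n4)ncnc32)[C@H](O)[C@@H]1O` gives 750 nM, and compound 2 `Cn1cccc1-c1ncnc2c1ncn2C1O[C@H](CO)[C@@H](O)[C@H]1O` gives 2000 nM. The change a 2.2-fold higher number from compound 1 to compound 2 (0.35 log units; beyond the scatter) lies beyond the scatter, whereas a 1.2-fold lower number from compound 1 to compound 3 (0.08 log units; within the scatter) does not.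

Compound 4 `OC[C@H]1OC(n2cnc3c(-c4ccsc4)ncnc32)[C@H](O)[C@@H]1O` differs from compound 1 in one place: thiophen-3-yl in place of pyridin-2-yl on an aromatic carbon. Both earlier steps replaced the same pyridin-2-yl with a five-membered aromatic ring, so they bear on this change. The 1H-pyrazol-3-yl step left the number essentially unchanged, while the 1-methyl-1H-pyrrol-2-yl step raised it modestly. Thiophen-3-yl carries neither the ring nitrogen of pyridin-2-yl nor the hydrogen-bond donor of 1H-pyrazol-3-yl, so a modest rise is expected, a 1.7-fold higher number from compound 1 to compound 4 (0.22 log units; within the scatter), though a result within the scatter cannot be ruled out. Compound 4 is therefore estimated at 1500 nM, in a range from 600 nM to 4000 nM.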

Compound 4, half-maximal inhibitory concentration: 1640 nM
Compound 4: middle estimate off by 1.1-fold (0.04 log units), on the low side, within the range that was stated.
By their numbers in this assay, from the lowest: compounds 3, 1, 4 and 2 (each within the scatter of the next, the first and the last beyond it).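

In this assay, the result shows that this aromatic carbon accepts a sulfur-containing five-membered ring in place of pyridin-2-yl with no clear change, with a 1.8-fold higher number from compound 1 to compound 4 (0.26 log units; within the scatter). Thiophen-3-yl also sits level with 1-methyl-1H-pyrrol-2-yl, with a 1.2-fold lower number from compound 2 to compound 4 (0.09 log units; within the scatter), but it separates from 1H-pyrazol-3-yl, with a 2.2-fold higher number from compound 3 to compound 4 (0.34 log units; beyond the scatter), so compound 3 now stands apart from two other five-membered rings, while compound 1 remains within the scatter of compound 3 and compound 4. No measurement here explains this difference among the five-membered rings.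

Whether a hetero atom in the ring matters at all remains open, since a plain phenyl ring is not among these compounds. On these data alone, whether a ring is needed here is also open, since the same carbon could carry an amine or a short alkyl chain instead.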